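The source may hold more compounds than are shown below. What is called first, only, known or untested is meant among the compounds shown, and "the series" means these compounds.

Compound 2 `CN(C)C(=O)CCNC(=O)c1cc(-c2ccc(F)cc2)no1` is one of three compounds from a single series measured in an ADME assay on microsomes from liver (Homo sapiens) for metabolic stability, with a stated time of 0.5 h, tested at 0.5 mg/mL; a lower number here means that less of the compound is left, a higher number that more of the compound is left. In this assay compound 2 gives 87%. Its closest neighbour in the numbers is compound 1 `CN(C)C(=O)CNC(=O)c1cc(-c2ccc(F)cc2)no1`, which gives 84%; the change a number 3 percentage points higher from compound 1 to compound 2 (within the scatter) lies within the scatter, so the two cannot be ordered. Compound 3 `CS(=O)(=O)N1CC2(CC(NC(=O)c3cc(-c4ccccc4)no3)C2)C1` gives 76%, a number that sits below compound 2 by more than the scatter, as the two values show.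

The untested compound 4 `CN(C)C(=O)CCNC(=O)c1cc(-c2ccccc2F)no1` differs from compound 2 only in one respect: 2-fluorophenyl in place of 4-fluorophenyl on an aromatic carbon. Among the measured compounds shown here, no measured step in this set moves a fluorine around the aromatic ring; the only step on record, from compound 1 to compound 2, concerns a chain and was within the scatter. There is therefore no measured basis for expecting a shift, and the estimate for compound 4 is a step of a number 2 percentage points lower from compound 2 to compound 4 (within the scatter) of no size beyond the scatter. Compound 4 is thus expected to give 85%, within a range from 72% to 95%.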

Compound 4, percent of the compound remaining: > 100%
Compound 4: a limit, no number (the forecaster's own chance of this, stated with the estimate: 0%); at least 15 percentage points between middle value and limit.
By their numbers in this assay, from the lowest: compounds 3, 1 and 2 (each within the scatter of the next, the first and the last beyond it). At a limit, above all of these: compound 4.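

In this assay, the exchange of 4-fluorophenyl for 2-fluorophenyl gives a number at least 13 percentage points higher from compound 2 to compound 4 (beyond the scatter). The two compounds have the same atoms, joined differently, so where the fluorine sits on this aromatic ring can move the read-out beyond the scatter, which the chain step, a number 3 percentage points higher from compound 1 to compound 2 (within the scatter), did not do. Compound 4 stands at a limit of the assay and not at a number, so the step has a lower bound but no full size: the limit of > 100% in this assay, at which 1 of the 4 values shown sits.

The compounds shown leave open whether a chlorine or a methyl group in place of the fluorine would behave in the same way, and whether 2-fluorophenyl would give a similar step on the shorter chain of compound 1. They also give no reason for the step.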